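Adding a methyl group to compound 3

The source may hold more compounds than are shown below. What is called first, only, known or untested is meant among the compounds shown, and "the series" means these compounds.

In a physicochemical assay for lipophilicity, measured as octanol-water partition, at pH 7.4 (on this read-out higher numbers stand for higher lipophilicity and lower numbers for lower lipophilicity), compound 1 `Cc1cc(-c2nc3ccccc3s2)ccc1N` gives 3.96. Compound 2 `Nc1ccc(-c2nc3ccccc3s2)cc1Cl` gives > 3.3, which is a limit and not a number. Compound 3 `O=S(=O)(O)Nc1ccc(-c2nc3ccccc3s2)cc1` gives 3.4, the lower of the two true numbers. Compound 4 `Cc1cc(-c2nc3ccccc3s2)ccc1NS(=O)(=O)O` differs from it by one change, methyl in place of hydrogen on an aromatic carbon. Going by the values given here, the one measured step, a step that the limit leaves unreadable from compound 1 to compound 2, concerns chloro in place of methyl, and its size stays unknown with the limit of > 3.3 in this assay, at which 1 of the 3 values shown sits. Compound 1 carries a methyl at 3.96 but no sulfoamino group, so it offers only a weak hint. A modest rise is expected, a number 0.40 log units higher from compound 3 to compound 4 (beyond the scatter). Compound 4 is estimated at 3.8, with an expected range from 3.3 to 4.3.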

Compound 4, distribution coefficient: 0.6
Estimate against measurement, compound 4: 3.20 log units above; the measured number lies below the stated range.
By their numbers in this assay, from the lowest: compound 4; then compound 3; then compound 1.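

In this assay methyl in place of hydrogen on this aromatic carbon, ortho to a sulfoamino group, gives a number 2.80 log units lower from compound 3 to compound 4 (beyond the scatter) and not a small shift. Sulfo in place of hydrogen on the nitrogen, with the methyl already present, gives a number 3.36 log units lower from compound 1 to compound 4 (beyond the scatter) and so the methyl in compound 1 says little about the same methyl in a compound carrying a sulfoamino group.

As far as these compounds go, whether an ethyl group at this carbon, or a carboxylic acid in place of the sulfoamino group, would give a fall of this kind stays open. No measurement shown bears on what lies behind this fall.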